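Ring-nitrogen alkyl chain in a sulfonamide anilinopyrimidine series

A few compounds are considered here, and "the series" means these few. Any claim that something is new, unique, unknown or untested is made for them only; others in the source may bear on it.

Compound 1 `Cn1nc(-c2ccnc(Nc3ccc(S(N)(=O)=O)cc3)n2)c2ccccc21` gives 940 nM in a functional assay on MCF7 cells (Homo sapiens) for antiproliferative activity, read by MTT assay, with a stated time of 72 h; a lower number here means a stronger inhibitor of growth, a higher number a weaker inhibitor of growth. Compound 2 `Cn1nc(-c2ccnc(Nc3cccc(S(N)(=O)=O)c3)n2)c2ccccc21` holds the same atoms joined differently; the difference between the two cores is not broken down here. In this assay compound 2 gives 2270 nM. Compound 3 `CCn1nc(-c2ccnc(Nc3ccc(S(N)(=O)=O)cc3)n2)c2ccccc21` differs from compound 1 by methyl in place of hydrogen on a saturated chain carbon bound to an aromatic nitrogen. In this assay compound 3 gives 2280 nM; the resulting step is a 2.4-fold higher number from compound 1 to compound 3 (0.38 log units; beyond the scatter). Compound 4 `CCn1nc(-c2ccnc(Nc3cccc(S(N)(=O)=O)c3)n2)c2ccccc21` differs from compound 2 by methyl in place of hydrogen on a saturated chain carbon bound to an aromatic nitrogen, the same change as that from compound 1 to compound 3, which occurs twice among these compounds. In this assay the expected step is a 2.3-fold higher number from compound 2 to compound 4 (0.36 log units; beyond the scatter), resting on the measured 2.4-fold higher number from compound 1 to compound 3 (0.38 log units; beyond the scatter) at the same place of change. Compound 4 is expected to give about 5200 nM, with a likely range from 2300 nM to 12000 nM.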

Compound 4, concentration for 50% growth inhibition: 7260 nM
Beside the measured number, compound 4's estimate is 1.4-fold (0.14 log units) below it; the range from low to high includes it.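

In this assay, methyl in place of hydrogen on the saturated chain carbon bound to the aromatic nitrogen, which turns methyl into ethyl, also gives a weaker result on the second core: a 3.2-fold higher number from compound 2 to compound 4 (0.50 log units; beyond the scatter). The two steps agree in direction and cannot be told apart in size: the same change on two cores in this assay, a 2.4-fold higher number (0.38 log units; beyond the scatter) from compound 1 to compound 3 and a 3.2-fold higher number (0.50 log units; beyond the scatter) from compound 2 to compound 4, 1.3-fold (0.12 log units) apart, within the scatter of two such steps. The change therefore carried over between these two cores, but two pairs in one assay do not show that it would carry to any other core, and they do not explain the loss.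

Open, from the compounds shown here alone, is whether a longer chain such as propyl continues this trend. Also open, going by these compounds, is how a chain ending in an amine or a carboxylic acid would compare with methyl.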